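A Methyl on the Ring, Two Limits, One Unknown

This account rests on a few compounds, and the source may have more. Where it says the series, first, only, none or still open, it means among the compounds named here.

The measured compounds in a functional assay on the whole organism for antagonist activity, with Mus musculus as the target; a higher number here means that more compound is needed for the effect, a lower number that less compound is needed:
compound 1, `CC(=O)N(C)C(C)C#CCn1ccnc1`, gives > 100 mg/kg, a limit of the assay;
compound 2, `CC(=O)N(C)C(C)C#CCn1ccnc1C`, gives 0.2 mg/kg;
compound 3, `COC(=O)N(C)C(C)C#CCn1ccnc1`, gives > 100 mg/kg, again a limit of the assay.

Compound 1 reports only a limit in this assay. Compound 3 likewise reports only a limit. These two compounds share the same core apart from one difference at the carbonyl carbon, (methoxy in place of methyl on a carbonyl carbon), and with both at the limit the step that the two limits leave unreadable from compound 1 to compound 3 cannot be sized. The weight of the picture rests on (the limit of > 100 mg/kg in this assay, at which 2 of the 3 values shown sit).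

Within the data shown here, the one readable step is the change (methyl in place of hydrogen on an aromatic carbon), which gave an at least 500-fold lower number from compound 1 to compound 2 (2.69 log units; beyond the scatter).

Compound 4, `COC(=O)N(C)C(C)C#CCn1cncc1C`, is not yet measured. It arises from compound 3 by the same kind of change, (methyl in place of hydrogen on an aromatic carbon), but the place is not the same: in compound 2 the methyl sits between two ring nitrogen atoms, whereas in compound 4 it sits next to the ring nitrogen and two ring bonds from the ring nitrogen. Among the measured compounds shown here, no measured pair shows what a methyl at that place does, and the carbonyl difference between the two cores is unreadable from the limits.

The step is therefore expected to be smaller and far less certain than an at least 500-fold lower number from compound 1 to compound 2 (2.69 log units; beyond the scatter), with an estimated at least 10-fold lower number from compound 3 to compound 4 (1.00 log units; beyond the scatter). Compound 4 is expected to give about 10 mg/kg in this assay, plausibly anywhere from 0.5 mg/kg to 150 mg/kg.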

Compound 4, dose for half-maximal effect: 6.6 mg/kg
The estimate for compound 4 lay 1.5-fold (0.18 log units) above the measured number; measured number inside the range.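

In this assay, methyl in place of hydrogen on an aromatic carbon gave an at least 15-fold lower number from compound 3 to compound 4 (1.18 log units; beyond the scatter), so the change that lowered the number on the core of compound 1 also lowered it on a second core, here with the methyl next to the ring atom that bears a large group. Set side by side, the two results show a shared direction on these two pairs, but they do not give a size that can simply be carried from one core to the other: the same change on two cores in this assay, an at least 500-fold lower number (2.69 log units; beyond the scatter) from compound 1 to compound 2 and an at least 15-fold lower number (1.18 log units; beyond the scatter) from compound 3 to compound 4; the limit leaves it open whether they differ. Each of the two steps starts from a limit and not from a true number, the methyl does not occupy the same ring place in compound 2 and compound 4, and so the two pairs do not establish a rule for every core or ring place: the limit of > 100 mg/kg in this assay, at which 2 of the 4 values shown sit.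

No pair shown keeps the core fixed while moving the methyl, so it remains open how much the ring place matters, and the step from compound 1 to compound 3 cannot be read, which leaves the effect of the methoxy in place of methyl on the carbonyl carbon unknown. On these data alone, it also remains open whether an ethyl group or a chlorine atom at either ring place would lower the number as the methyl does.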